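A few compounds are considered here, and "the series" means these few. Any claim that something is new, unique, unknown or untested is made for them only; others in the source may bear on it.

Measured in a functional assay on PC-9 cells (Homo sapiens) for inhibition, read by MTT assay, with a stated time of 72 h; on this read-out higher numbers stand for weaker inhibition and lower numbers for stronger inhibition:

compound 1 `Cc1cc(Nc2cc(-c3ccccc3)[nH]n2)n2nc(SCc3ccc(Br)cc3)nc2n1`: 4760 nM
compound 2 `Cc1cc(Nc2cc(-c3ccccc3)[nH]n2)n2nc(SCc3ccc(Cl)cc3)nc2n1`: 6710 nM

Among the measured compounds shown here, compound 2 stands at the higher of the two numbers, with compound 1 close by; the single measured step, a 1.4-fold higher number from compound 1 to compound 2 (0.15 log units; within the scatter), is a halogen swap within the scatter. Compound 3 `Cc1cc(Nc2cc(-c3ccccc3)[nH]n2)n2ncnc2n1` differs from compound 2 by hydrogen in place of (4-chlorobenzyl)sulfanyl on an aromatic carbon. The halogen swap does not bear on removal of the whole group, so the data give no direct guide to the size of this step; the loss of a group of this size is expected to weaken inhibition, and compound 3 is estimated at 20000 nM (range 5000 nM to 80000 nM), a step of a 3.0-fold higher number from compound 2 to compound 3 (0.47 log units; beyond the scatter) expected in this assay.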

Compound 3, half-maximal inhibitory concentration: > 50000 nM
Compound 3 gave a limit, no number (the forecaster's own chance of this, stated with the estimate: 25%); at least 2.5-fold (0.39 log units) between middle value and limit.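

In this assay, compound 3 gives a limit and not a number: the limit of > 50000 nM in this assay, at which 1 of the 3 values shown sits. Replacing (4-chlorobenzyl)sulfanyl with hydrogen gives an at least 7.4-fold higher number from compound 2 to compound 3 (0.87 log units; beyond the scatter), and replacing (4-bromobenzyl)sulfanyl with hydrogen gives an at least 10-fold higher number from compound 1 to compound 3 (1.02 log units; beyond the scatter). The substituent on this aromatic carbon, between two ring nitrogen atoms, therefore matters for the inhibition seen with compound 1 and compound 2, which the halogen swap alone could not show.

Which part of the group matters remains open, whether the sulfur, the benzyl unit or the halogenated ring. From the compounds shown here alone, how a methylsulfanyl group, or an amine in place of the sulfur, would read at this carbon also remains open.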